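A methyl added to an inactive pair of aryl compounds

This account rests on a few compounds, and the source may have more. Where it says the series, first, only, none or still open, it means among the compounds named here.

Compound 2 `Brc1ccc(-c2cc3ccccc3o2)cc1` in an assay on cells for inhibition of Amine oxidase [flavin-containing] A (Homo sapiens), read by fluorescence and Amplex Red, with a stated time of 15 min (a lower number here means a stronger inhibitor, a higher number a weaker inhibitor), gives > 100000 nM, which is a limit of the assay rather than a number. Compound 1 `Cc1ccc2oc(-c3cccc(Br)c3)cc2c1` in this assay gives > 100000 nM, again a limit. Both shown values sit at the limit of > 100000 nM in this assay, at which 2 of the 2 values shown sit, so nothing measured lies below that point. Compound 3 `Cc1cccc2cc(-c3ccc(Br)cc3)oc12` differs from compound 2 by methyl in place of hydrogen on an aromatic carbon. Going by the values given here, no step between measured compounds has been observed, and the expected change in this assay is none beyond the scatter. Compound 3 is expected to give 150000 nM, with a range from 40000 nM to 600000 nM. The step from compound 2 to compound 3 is estimated as a step that the limit leaves unreadable from compound 2 to compound 3, most likely again ending in a limit.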

Compound 3, half-maximal inhibitory concentration: 100000 nM
Beside the measured number, compound 3's estimate is 1.5-fold (0.18 log units) above it; the measured number falls inside the stated range.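

In this assay compound 3 gives 100000 nM, a measured number rather than a limit, so methyl in place of hydrogen on this aromatic carbon, ortho to a fused ring, yields no strong inhibitor. This change gives a number no higher from compound 2 to compound 3 (the limit leaves the size open). The size of the step from hydrogen to methyl cannot be read, because the comparison rests on a limit: the limit of > 100000 nM in this assay, at which 2 of the 3 values shown sit.

Still open, as far as these compounds go, is whether a larger or differently built group at this carbon, such as an amine, a carboxylic acid or a longer chain, would give a clearly lower value.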